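The source may hold more compounds than are shown below. What is called first, only, known or untested is meant among the compounds shown, and "the series" means these compounds.

Notes on the series. Compound 1 `Cc1c[se]c(NNC(=O)c2ccc(Cl)cc2)n1` and compound 2 `O=C(NNc1nc(-c2ccccc2)c[se]1)c1ccc(Cl)cc1` share one core; compound 3 `CC(=O)N(C(=O)c1ccccc1)N(C(C)=O)c1nc(C)c[se]1` and compound 4 `CC(=O)N(C(=O)c1ccccc1)N(C(C)=O)c1nc(-c2ccccc2)c[se]1` share another, and the difference between the two cores is not broken down here. In a functional assay on DU-145 cells (Homo sapiens) for cytotoxicity, read by XTT assay, with a stated time of 72 h (a lower number here means a stronger inhibitor, a higher number a weaker inhibitor), compound 1 gives only a limit, > 79400 nM. In this assay compound 2 gives 65100 nM. Going by these compounds, the change between them is phenyl in place of methyl on an aromatic carbon, and the step is an at least 1.2-fold lower number from compound 1 to compound 2 (0.08 log units; that floor lies within the scatter); its true size stays open because compound 1 sits at the limit (the limit of > 79400 nM in this assay, at which 1 of the 3 values shown sits). In this assay compound 3 gives only a limit, > 68600 nM. The same change, (phenyl in place of methyl on an aromatic carbon), is made on compound 3. Because compound 3 sits at the limit of > 68600 nM in this assay, at which 1 of the 3 values shown sits, and the measured step lies within the scatter, only a small step is expected, an at least 1.1-fold lower number from compound 3 to compound 4 (0.05 log units; that floor lies within the scatter). Compound 4 is therefore expected near 60000 nM, between 30000 nM and 100000 nM, with a real chance that only a limit is reported.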

Compound 4, half-maximal inhibitory concentration: > 58600 nM
Compound 4 was reported as a limit; the forecaster's own chance of this, stated with the estimate: 55%; the middle value is on the limit's open side.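

Compound 3 and compound 4 each give only a limit in this assay, so the step between them cannot be read. The compounds shown leave open whether phenyl in place of methyl on an aromatic carbon changes the number on either core.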